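Adding a Methoxy Group to Compound 1: What to Expect

The source may hold more compounds than are shown below. What is called first, only, known or untested is meant among the compounds shown, and "the series" means these compounds.

For the measured compounds named here, compound 1 `O=C(NOCc1ccccc1)c1cn(-c2ccccc2)nc1-c1ccccc1` is the weaker of the two measured compounds in a functional assay on HeLa cells (Homo sapiens) for antiproliferative activity, read by MTT assay, with a stated time of 48 h, in the presence of a further agent that is not named here; a lower number here means a stronger inhibitor of growth, a higher number a weaker inhibitor of growth: compound 1 gives 8830 nM, while its only neighbour, compound 2 `O=C(NOCc1ccc(Cl)cc1Cl)c1cn(-c2ccccc2)nc1-c1ccccc1`, gives 5100 nM. Going by the values given here, the one measured step, a 1.7-fold lower number from compound 1 to compound 2 (0.24 log units; within the scatter), replaces the phenyl on the saturated chain carbon bound to an oxygen with a 2,4-dichlorophenyl and stays within the scatter, so the two numbers cannot be told apart with confidence.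

Compound 3 `COc1ccc(-c2nn(-c3ccccc3)cc2C(=O)NOCc2ccccc2)cc1` differs from compound 1 in a different place: methoxy in place of hydrogen on an aromatic carbon, which, seen one bond further out, reads phenyl to 4-methoxyphenyl. Among the compounds with values here, no measured step touches this ring, so the single step from compound 1 to compound 2 gives no direct guide, and it says only that a change on the other ring made no difference beyond the scatter. With nothing pointing strongly either way, the step of a 1.1-fold lower number from compound 1 to compound 3 (0.04 log units; within the scatter) is expected to stay small, within the scatter, in this assay. Compound 3 is therefore estimated at 8000 nM, with a range from 2500 nM to 25000 nM.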

Compound 3, concentration for 50% growth inhibition: 2640 nM
Estimate against measurement, compound 3: 3.0-fold (0.48 log units) above; low and high end bracket the measured number.
By their numbers in this assay, from the lowest: compounds 3, 2 and 1 (each within the scatter of the next, the first and the last beyond it).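

In this assay, the step of a 3.3-fold lower number from compound 1 to compound 3 (0.52 log units; beyond the scatter) is the only change shown here that goes beyond the scatter, so this aromatic carbon is a place where a small substituent can shift the read-out. The earlier step, a 1.7-fold lower number from compound 1 to compound 2 (0.24 log units; within the scatter), concerned a different ring and could not establish that any change in the molecule mattered, whereas phenyl to 4-methoxyphenyl gives a modest but readable gain in growth inhibition, although it rests on a single pair of compounds. Nothing available here bears on why the methoxy group has this effect.

The compounds shown leave open whether the gain is particular to methoxy or would also appear with another group on the same carbon, such as a hydroxyl, a fluorine, an ethoxy or a dimethylamino group. They also leave open whether the 4-methoxyphenyl change and the 2,4-dichlorophenyl change would add up in one molecule, or whether the gain depends on the methoxy group being para to the large group rather than elsewhere on that ring.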